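Swapping a pentylcarbonyl for phenyl on the benzyl arm

The compounds below may be only part of what the source reports. "The series", "measured", "known", "first", "only" and "open" are said of these compounds alone.

Compound 1, `CCCCCC(=O)c1ccc(CN(CCCCCCC(=O)O)S(C)(=O)=O)cc1`: in an assay on HEK293 cells for inhibition of prostaglandin E2 receptor EP2 subtype (Rattus norvegicus) (a higher number here means a weaker inhibitor, a lower number a stronger inhibitor), compound 1 gives 636 nM.
Compound 2, `CC(C)(C)c1ccc(CN(Cc2cccc(OCC(=O)O)c2)S(C)(=O)=O)cc1`: in this assay compound 2 gives 792 nM.

Compound 1 has the lower of the two numbers, but its value and that of compound 2 sit within the usual scatter of each other, so neither can be called the stronger inhibitor. Compound 3, `CS(=O)(=O)N(CCCCCCC(=O)O)Cc1ccc(-c2ccccc2)cc1`, is not yet measured. It differs from compound 1 in one place: phenyl in place of pentylcarbonyl on an aromatic carbon. Within the data shown here, no measured pair shows this change, so the step from compound 1 to compound 3 in this assay is expected to be small, most likely within the scatter, with a slight lean toward a weaker inhibitor, giving an estimated 1.4-fold higher number from compound 1 to compound 3 (0.15 log units; within the scatter). Compound 3 is therefore expected to give about 900 nM, within a range of 250 nM to 3200 nM.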

Compound 3, half-maximal inhibitory concentration: 289 nM
The estimate for compound 3 lay 3.1-fold (0.49 log units) above the measured number, within the range that was stated.
By their numbers in this assay, from the lowest: compound 3; then compounds 1 and 2 (each within the scatter of the next).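

In this assay, phenyl in place of pentylcarbonyl gives a 2.2-fold lower number from compound 1 to compound 3 (0.34 log units; beyond the scatter) and so brings a modest gain in inhibition. At this aromatic carbon, para to a large group, the carbonyl and its hydrogen-bond acceptor are therefore not required, and an aromatic ring of carbon only is tolerated. Nothing measured explains the gain.

One step cannot show whether the gain comes from adding the ring or from losing the carbonyl. A cyclohexyl ring or a plain pentyl chain at this position would separate these two possibilities.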